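Trifluoromethyl for Methyl on the Aniline of Compound 2

The compounds below may be only part of what the source reports. "The series", "measured", "known", "first", "only" and "open" are said of these compounds alone.

Of the compounds shown here, three have so far been measured in a functional assay on MCF7 cells (Homo sapiens) for cytotoxicity, read by sulforhodamine B assay, with a stated time of 48 h; a lower number here means a stronger inhibitor, a higher number a weaker inhibitor. Compound 3 `Cc1ccc(Nc2nccc(-c3cnc4ccccc4c3)n2)cc1` gives 50000 nM. Compound 1 `FC(F)(F)c1ccc(Nc2nccc(-c3cnc4ccccc4c3)n2)cc1` reaches only a limit of the assay, > 50000 nM. That limit, (the limit of > 50000 nM in this assay, at which 1 of the 3 values shown sits), leaves the size of the step from compound 3 open. For the measured compounds named here, the change between the two is trifluoromethyl in place of methyl on an aromatic carbon, and the step of a number no lower from compound 3 to compound 1 (the limit leaves the size open) shows only that the number did not fall. Compound 2 `Cc1ccc(Nc2nccc(-c3c(C)nc4ccccn34)n2)cc1` gives 59 nM, the lowest of the measured values; the difference between its core and the core of compound 3 is not broken down here.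

Compound 4 `Cc1nc2ccccn2c1-c1ccnc(Nc2ccc(C(F)(F)F)cc2)n1` has not yet been measured. It differs from compound 2 by trifluoromethyl in place of methyl on an aromatic carbon, the same kind of change as that from compound 3 to compound 1, at a place described in the same words. Since the earlier step is hidden by the limit (the limit of > 50000 nM in this assay, at which 1 of the 3 values shown sits), it offers little guidance on size, and compound 2 is expected to lose a modest amount of potency, an expected step of a 2.5-fold higher number from compound 2 to compound 4 (0.41 log units; beyond the scatter). Compound 4 is therefore estimated at about 150 nM, expected to fall between 40 nM and 800 nM.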

Compound 4, half-maximal inhibitory concentration: 66 nM
The estimate for compound 4 lay 2.3-fold (0.36 log units) above the measured number, and the stated range covers the measured number.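

In this assay, trifluoromethyl in place of methyl on an aromatic carbon gives a 1.1-fold higher number from compound 2 to compound 4 (0.05 log units; within the scatter), so on this core the measurement does not tell the two groups apart. Set beside the same change on the other core, the comparison stops short of a size: the same change on two cores in this assay, a number no lower (the limit leaves the size open) from compound 3 to compound 1 and a 1.1-fold higher number (0.05 log units; within the scatter) from compound 2 to compound 4; the limit leaves it open whether they differ For compound 1 the value > 50000 nM is a limit of the assay and not a number, so the step on that core cannot be read, and a single readable step shows neither that the change carries from one core to the other nor that it does not.

The compounds shown leave open how the core of compound 2 would respond to other groups at the same place, such as a chlorine atom, a methoxy group, an amine or a carboxylic acid. They also leave open whether a longer chain there would give a number in the same range as compound 2 and compound 4.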